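From Pyridin-3-yl to 4-Fluorophenyl on the Carbonyl Carbon

This account rests on a few compounds, and the source may have more. Where it says the series, first, only, none or still open, it means among the compounds named here.

Of the compounds shown here, three sharing one core have been measured in a functional assay on SK-OV-3 cells (Homo sapiens) for cytotoxicity, read by MTT assay, with a stated time of 48 h; on this read-out lower numbers stand for stronger inhibition and higher numbers for weaker inhibition. Compound 1 `O=C(/C=C/c1ccc2c(c1)B(O)OC2)c1ccc(-c2ccccc2)cc1` gives 4900 nM. Compound 2 `O=C(/C=C/c1ccc2c(c1)B(O)OC2)c1ccco1` gives 20700 nM, and compound 3 `O=C(/C=C/c1ccc2c(c1)B(O)OC2)c1cccnc1` gives 18500 nM, the second highest of the three numbers: the step of a 1.1-fold lower number from compound 2 to compound 3 (0.05 log units; within the scatter) separates it from its nearest neighbour, while compound 1 sits at a lower number, beyond the scatter. Compound 4 `O=C(/C=C/c1ccc2c(c1)B(O)OC2)c1ccc(F)cc1` differs from compound 3 by 4-fluorophenyl in place of pyridin-3-yl on a carbonyl carbon. Within the data shown here, only one measured step alters the group on the carbonyl carbon, and it was small; compound 1, carrying a ring of carbon only there, shows a lower number. A modest downward step a 2.1-fold lower number from compound 3 to compound 4 (0.31 log units; beyond the scatter) is therefore expected. Compound 4 is estimated at 9000 nM, within 4000 nM to 20000 nM.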

Compound 4, half-maximal inhibitory concentration: 1400 nM
For compound 4 the middle estimate is 6.4-fold (0.81 log units) above the measured one; measured number below the stated range.
By their numbers in this assay, from the lowest: compound 4; then compound 1; then compounds 3 and 2 (each within the scatter of the next).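

Among these compounds, the group on the carbonyl carbon matters far more than the one earlier step suggested: in this assay the change gives a 13-fold lower number from compound 3 to compound 4 (1.12 log units; beyond the scatter) and a 15-fold lower number from compound 2 to compound 4 (1.17 log units; beyond the scatter), both large. Fluoro in place of phenyl on the aromatic carbon also counts, with a 3.5-fold lower number from compound 1 to compound 4 (0.54 log units; beyond the scatter), so the substituent on that carbon ring moves the number too. Nothing measured here gives a reason for these steps.

As far as these compounds go, how a plain phenyl would compare remains open. So does the effect of an amine or a carboxylic acid on that ring.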